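From compound 3 to compound 4: same atoms, joined differently

The compounds below may be only part of what the source reports. "The series", "measured", "known", "first", "only" and "open" are said of these compounds alone.

compound 1 `C[C@H]1[C@H](N)CN1c1cc2c(cc1F)c(=O)c(C(=O)O)cn2C1CC1` gives 9.9 ug/mL
compound 2 `CC[C@H]1[C@@H](N)CN1c1cc2c(cc1F)c(=O)c(C(=O)O)cn2C1CC1` gives 42.2 ug/mL
compound 3 `C[C@H]1N(c2cc3c(cc2F)c(=O)c(C(=O)O)cn3C2CC2)C[C@]1(C)N` gives 1.3 ug/mL

In a physicochemical assay for solubility, at pH 7.4 (on this read-out higher numbers stand for higher solubility and lower numbers for lower solubility), compound 3 stands lowest of the three and beyond the scatter from both others, with 1.3 ug/mL as its number. The next compound, compound 4 `CN[C@H]1CN(c2cc3c(cc2F)c(=O)c(C(=O)O)cn3C2CC2)[C@@H]1C`, has not yet been measured. Its difference from compound 3 reads a group of 7 heavy atoms (5 carbon, 2 nitrogen; one four-membered non-aromatic ring with 1 hetero atom) in place of a group of 7 heavy atoms (5 carbon, 2 nitrogen; one four-membered non-aromatic ring with 1 hetero atom), on an aromatic carbon and the two have the same atoms, joined differently.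

Among the compounds with values here, three measured steps bear on this change, each a swap of one group for another at the same place on the shared core. The modest ones are a 4.3-fold higher number from compound 1 to compound 2 (0.63 log units; beyond the scatter) and a 7.6-fold lower number from compound 1 to compound 3 (0.88 log units; beyond the scatter) and the large one is a 32-fold lower number from compound 2 to compound 3 (1.51 log units; beyond the scatter) between two groups that also hold the same atoms. Equal atoms therefore give no promise of equal numbers here. With compound 3 at 1.3 ug/mL and compound 1 at 9.9 ug/mL and compound 2 at 42.2 ug/mL above it, a move upward is expected rather than a further fall. What is expected in this assay is a 5.4-fold higher number from compound 3 to compound 4 (0.73 log units; beyond the scatter) and this would be a modest step. Within the data shown here, no measured compound carries the group that enters, so the range stays wide. The estimate for compound 4 is 7 ug/mL with an expected range from 1.5 ug/mL to 35 ug/mL in this assay once it is measured.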

Compound 4, solubility: 9.2 ug/mL
For compound 4 the middle estimate is 1.3-fold (0.12 log units) below the measured one; low and high end bracket the measured number.
By their numbers in this assay, from the lowest: compound 3; then compounds 4 and 1 (each within the scatter of the next); then compound 2.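

Compound 4 shows that the same atoms in this position, on an aromatic carbon ortho to a fluoro group, can give a third distinct level in this assay, not just the two seen before. The new isomer stands apart from both earlier ones, with a 7.1-fold higher number from compound 3 to compound 4 (0.85 log units; beyond the scatter) and a 4.6-fold lower number from compound 2 to compound 4 (0.66 log units; beyond the scatter), so all three arrangements of these atoms are separated by more than the scatter. Among the groups of 7 heavy atoms, this is also the first to stay level with the smaller group of compound 1, with a 1.1-fold lower number from compound 1 to compound 4 (0.03 log units; within the scatter), whereas the groups of compound 2 and compound 3 both moved the number beyond the scatter.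

Nothing in hand accounts for these differences between groups of identical atoms. On these data alone, with only these four compounds, it remains open whether any rule links the arrangement of the atoms to the number, and how a propyl chain or a hydroxyl group on the four-membered ring would compare in this assay.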